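A New Aryl Group on Compound 3

The compounds below may be only part of what the source reports. "The series", "measured", "known", "first", "only" and "open" are said of these compounds alone.

Of the compounds shown here, three sharing one core have been tested so far in a functional assay on PC-3 cells (Homo sapiens) for cytotoxicity, read by MTT assay, with a stated time of 72 h (on this read-out higher numbers stand for weaker inhibition and lower numbers for stronger inhibition), on this read-out. Compound 1 (`COc1cc2ncnc(Nc3ccc(F)c(Cl)c3)c2cc1NC(=O)N/N=C/c1cccc(Br)c1`) is recorded as "not active" (no number reported) without a number. For the measured compounds named here, compound 2 (`COc1cc2ncnc(Nc3ccc(F)c(Cl)c3)c2cc1NC(=O)N/N=C/c1cccc(Cl)c1Cl`) gives 24400 nM and compound 3 (`COc1ccc(/C=N/NC(=O)Nc2cc3c(Nc4ccc(F)c(Cl)c4)ncnc3cc2OC)cc1`) gives 16500 nM in the same test, so compound 3 stands level with compound 2, the only other compound with a number. Compound 4 (`CCN(CC)c1ccc(/C=N/NC(=O)Nc2cc3c(Nc4ccc(F)c(Cl)c4)ncnc3cc2OC)c(O)c1`) has 4-(diethylamino)-2-hydroxyphenyl in place of 4-methoxyphenyl on a carbon with a double bond to nitrogen. Going by the values given here, one measured step bears on this change: a 1.5-fold lower number from compound 2 to compound 3 (0.17 log units; within the scatter) at that same place. Compound 1, with another group there, gave no number at all, so that outcome remains possible. Among the compounds with values here, no measured compound carries the entering group, so no shift beyond the scatter is expected in this assay for this change. The expected change is a 1.4-fold lower number from compound 3 to compound 4 (0.14 log units; within the scatter) in size. For compound 4 the estimated value is 12000 nM with an expected range of 2500 nM to 45000 nM overall.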

Compound 4, half-maximal inhibitory concentration: 34300 nM
For compound 4 the middle estimate is 2.9-fold (0.46 log units) below the measured one; the range from low to high includes it.
By their numbers in this assay, from the lowest: compounds 3, 2 and 4 (each within the scatter of the next, the first and the last beyond it).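

In this assay, for the compounds shown here, the exchange on the carbon with a double bond to nitrogen gave a 2.1-fold higher number from compound 3 to compound 4 (0.32 log units; beyond the scatter) and thus the first modest step at this place to lie beyond the scatter, so the group there can shift the number, if only slightly, and the larger 4-(diethylamino)-2-hydroxyphenyl did not improve on 4-methoxyphenyl. Against the 2,3-dichlorophenyl group, the same entering group gave a 1.4-fold higher number from compound 2 to compound 4 (0.15 log units; within the scatter) and so cannot be told apart from it in this test. Nothing available accounts for the step from compound 3 to compound 4.

The hydroxy and diethylamino groups enter together, so the compounds shown leave open which of them carries the step. Also open, from the compounds shown here alone, is how a morpholine or a carboxylic acid on this aryl ring would read in this assay here.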